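This account rests on a few compounds, and the source may have more. Where it says the series, first, only, none or still open, it means among the compounds named here.

Working notes on the series.

Compound 1 `CC(C)C[C@@H](/C=N/NC(N)=O)NC(=O)[C@@H](NS(=O)(=O)c1ccc(F)cc1)C(C)C` gives 680 nM in an assay on isolated protein for inhibition of Calpain-1 catalytic subunit (Sus scrofa); on this read-out higher numbers stand for weaker inhibition and lower numbers for stronger inhibition. Within the data shown here, compound 2 `CC(C)C[C@@H](/C=N/N1CCOCC1)NC(=O)[C@@H](NS(=O)(=O)c1ccc(F)cc1)C(C)C` gives 790 nM in this assay, and the step of a 1.2-fold higher number from compound 1 to compound 2 (0.07 log units; within the scatter) is the only comparison at hand. Compound 2 thus holds the higher of the two numbers, with compound 1 within the scatter of it, so no order between the two can be read.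

Compound 3 `CC(C)[C@H](NS(=O)(=O)c1ccc(F)cc1)C(=O)NC/C=N/N1CCOCC1` differs from compound 2 by hydrogen in place of isobutyl on a saturated chain carbon bound to an amide-type nitrogen and a carbon with a double bond to nitrogen. Among the measured compounds shown here, neither measured compound varies at this place; the single step from compound 1 to compound 2 concerns the group on the double-bonded nitrogen and does not bear on the change to compound 3. For the measured compounds named here, no measured step therefore supports a numerical expectation, and the guess rests only on the removal of a four-carbon chain from the core. The estimate for compound 3 is a step of a 19-fold higher number from compound 2 to compound 3 (1.28 log units; beyond the scatter) towards weaker inhibition. Compound 3 is expected to give about 15000 nM in this assay, in a range from 3000 nM to 80000 nM.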

Compound 3, half-maximal inhibitory concentration: 6200 nM
Compound 3: the middle estimate sits 2.4-fold (0.38 log units) above what was measured, and the stated range covers the measured number.
By their numbers in this assay, from the lowest: compounds 1 and 2 (each within the scatter of the next); then compound 3.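

In this assay, among these compounds, this is the first place where a single change gives a difference beyond the scatter: hydrogen in place of isobutyl gives a 7.8-fold higher number from compound 2 to compound 3 (0.89 log units; beyond the scatter) and so goes with weaker inhibition. The earlier pair differs only in the group on the double-bonded nitrogen and gave no readable order, so of the two places varied so far, only the saturated chain carbon shows an effect on the number. Nothing at hand explains the size of this step.

The compounds shown leave open how a methyl group, a longer chain or a benzyl group would read at this place, and so whether the number follows the size of the chain. They also leave open whether hydrogen in place of isobutyl gives a step of similar size with the ureido group of compound 1.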